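Thiophene carboxamide series: cytotoxicity at a single concentration

The compounds below may be only part of what the source reports. "The series", "measured", "known", "first", "only" and "open" are said of these compounds alone.

Compound 1 `CN1CCc2c(sc(NC(=O)c3ccc(Cl)cc3)c2C(N)=O)C1` is the reference of the set. In an ADME assay on RAW264.7 cells (Mus musculus) for cytotoxicity, read by MTT assay, with a stated time of 48 h, tested at 50 uM (a higher number here means more inhibition at the concentration tested (going by the name of the read-out), a lower number less inhibition), compound 1 gives 38.5%. Compound 2 `CC(C)(C)OC(=O)N1CCc2c(sc(NC(=O)c3ccc(Cl)cc3)c2C(N)=O)C1` carries tert-butoxycarbonyl in place of methyl on an amine nitrogen in a ring; in this assay compound 2 gives 37.3%, so that a number 1.2 percentage points lower from compound 1 to compound 2 (within the scatter). Compound 3 `CN1CCc2c(sc(NC(=O)c3ccc(OCc4ccccc4)cc3)c2C(N)=O)C1` differs from compound 1 in the other part of the molecule, (benzyloxy in place of chloro on an aromatic carbon); in this assay compound 3 gives 37.6%, giving a number 0.9 percentage points lower from compound 1 to compound 3 (within the scatter). All three numbers thus lie within the scatter of one another, and no order among them can be read.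

Compound 4 `CC(C)(C)OC(=O)N1CCc2c(sc(NC(=O)c3ccc(OCc4ccccc4)cc3)c2C(N)=O)C1` is not yet measured. It stands to compound 3 as compound 2 stands to compound 1: tert-butoxycarbonyl in place of methyl on an amine nitrogen in a ring. The place of the change is the same word for word in both pairs, so this is the same change made twice in the set, the only difference between the two cores being the one given above for compound 3 against compound 1. From compound 3 to compound 4 a step of the size a number 1.1 percentage points lower from compound 3 to compound 4 (within the scatter) is expected, resting on the measured a number 1.2 percentage points lower from compound 1 to compound 2 (within the scatter), which stayed within the scatter. For compound 4 in this assay the estimate is 36.5%, expected to fall between 27% and 46%.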

Compound 4, a percentage reported as inhibition, at one concentration (the size of the read-out at that concentration, not a potency): 52.1%
For compound 4 the middle estimate is 15.6 percentage points below the measured one; the whole stated range lies below it.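

In this assay, tert-butoxycarbonyl in place of methyl on an amine nitrogen in a ring does not carry from the core of compound 1 to the core of compound 3, giving a number 14.5 percentage points higher from compound 3 to compound 4 (beyond the scatter): the same change on two cores in this assay, a number 1.2 percentage points lower (within the scatter) from compound 1 to compound 2 and a number 14.5 percentage points higher (beyond the scatter) from compound 3 to compound 4, 15.7 percentage points apart, beyond the scatter of two such steps Benzyloxy in place of chloro on an aromatic carbon likewise does not carry over once tert-butoxycarbonyl is present, giving a number 14.8 percentage points higher from compound 2 to compound 4 (beyond the scatter): the same change on two cores in this assay, a number 0.9 percentage points lower (within the scatter) from compound 1 to compound 3 and a number 14.8 percentage points higher (beyond the scatter) from compound 2 to compound 4, 15.7 percentage points apart, beyond the scatter of two such steps Both comparisons rest on the same four compounds and describe a single departure from additivity, so they show that a step within the scatter on one core need not hold on another, but not why this happens or whether it extends beyond this set.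

The compounds shown leave open whether the higher number in compound 4 depends on these two exact groups or would also appear with, for example, an acetyl group or a free amine on the ring nitrogen. They also leave open what a methoxy group or a carboxylic acid on the aromatic carbon would give alongside tert-butoxycarbonyl.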